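One Aryl Exchange, Seen Twice on Two Related Cores

The source may report more compounds than this note shows. Statements on the series, on what has been measured and on what is new or still open speak of the compounds shown alone.

Compounds measured so far:
compound 1 `COc1ccc(C(=O)n2c(-c3cn(C)c4ccccc34)nc3ccccc32)cc1OC`: 8400 nM
compound 2 `Cn1cc(-c2nc3ccccc3n2C(=O)c2ccccc2Br)c2ccccc21`: 68200 nM
compound 3 `COc1ccc(C(=O)n2c(-c3cn(C)c4ccc(Br)cc34)nc3ccccc32)cc1OC`: 9700 nM

All three numbers come from a functional assay on HepG2 cells (Homo sapiens) for inhibition, read by MTT assay, with a stated time of 24 h; on this read-out lower numbers stand for stronger inhibition of growth and higher numbers for weaker inhibition of growth. Compound 2 differs from compound 1 by 2-bromophenyl in place of 3,4-dimethoxyphenyl on a carbonyl carbon, and that change made an 8.1-fold higher number from compound 1 to compound 2 (0.91 log units; beyond the scatter). Compound 3 differs from compound 1 by bromo in place of hydrogen on an aromatic carbon, and here a 1.2-fold higher number from compound 1 to compound 3 (0.06 log units; within the scatter), so the values of compound 1 and compound 3 cannot be ordered.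

Compound 4 `Cn1cc(-c2nc3ccccc3n2C(=O)c2ccccc2Br)c2cc(Br)ccc21` has not yet been measured in this assay. It differs from compound 3 by 2-bromophenyl in place of 3,4-dimethoxyphenyl on a carbonyl carbon. Within the data shown here, this is the same change as the one from compound 1 to compound 2, at the same place; the two cores differ only by bromo in place of hydrogen on an aromatic carbon.

The step from compound 3 to compound 4 is expected to be about an 8.0-fold higher number from compound 3 to compound 4 (0.91 log units; beyond the scatter), set beside the earlier 8.1-fold higher number from compound 1 to compound 2 (0.91 log units; beyond the scatter), an expectation that rests on compound 3 giving 9700 nM and on the earlier step having gone beyond the scatter. Compound 4 is therefore estimated at 78000 nM, expected to lie between 30000 nM and 200000 nM.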

Compound 4, concentration for 50% growth inhibition: 72100 nM
Estimate against measurement, compound 4: 1.1-fold (0.03 log units) above; the measured number falls inside the stated range.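

In this assay, 2-bromophenyl in place of 3,4-dimethoxyphenyl on the carbonyl carbon gave a 7.4-fold higher number from compound 3 to compound 4 (0.87 log units; beyond the scatter), and this step agrees with the one seen on the core without the added bromo: the same change on two cores in this assay, an 8.1-fold higher number (0.91 log units; beyond the scatter) from compound 1 to compound 2 and a 7.4-fold higher number (0.87 log units; beyond the scatter) from compound 3 to compound 4, 1.1-fold (0.04 log units) apart, within the scatter of two such steps Bromo in place of hydrogen on an aromatic carbon gave a 1.1-fold higher number from compound 2 to compound 4 (0.02 log units; within the scatter), so with 2-bromophenyl on the carbonyl carbon, as with 3,4-dimethoxyphenyl, that change leaves no difference that can be read: the same change on two cores in this assay, a 1.2-fold higher number (0.06 log units; within the scatter) from compound 1 to compound 3 and a 1.1-fold higher number (0.02 log units; within the scatter) from compound 2 to compound 4, 1.1-fold (0.04 log units) apart, within the scatter of two such steps Across these four compounds the aryl exchange therefore carried over from one core to the other, but this rests on a single exchange, on two cores separated by one bromo and in one assay, and it shows neither why the number rises nor that the step would hold on a more different core.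

The compounds shown leave open how an unsubstituted phenyl or a phenyl bearing a single methoxy group would stand on the carbonyl carbon. They also leave open whether the step would persist with an amine or a carboxylic acid on that ring.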